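A Carboxy Group in Place of Hydrogen on Compound 1

A few compounds are considered here, and "the series" means these few. Any claim that something is new, unique, unknown or untested is made for them only; others in the source may bear on it.

Three compounds have been measured in an assay for binding affinity to 17-beta-hydroxysteroid dehydrogenase type 1 (Homo sapiens), with a stated time of 20 min, tested at 1 uM; a higher number here means more inhibition at the concentration tested (going by the name of the read-out), a lower number less inhibition:
compound 1, `Oc1cccc2cc(-c3ccccc3)ccc12`, gives < 10%, which is a limit of the assay and not a number.
compound 2, `N#Cc1ccc(-c2ccc3c(O)cccc3c2)cc1`, gives 16%.
compound 3, `CC(=O)c1ccc(-c2ccc3c(O)cccc3c2)cc1`, gives 16%.

Compound 1 therefore stands at the floor of this assay, as the line the limit of < 10% in this assay, at which 1 of the 3 values shown sits, records, and only an upper bound is known for it. Compound 2 carries a cyano group where compound 1 has hydrogen, and the step is a number at least 6 percentage points higher from compound 1 to compound 2 (that floor lies within the scatter). Compound 3 carries an acetyl group instead, and the step is a number at least 6 percentage points higher from compound 1 to compound 3 (that floor lies within the scatter). Between the two substituted compounds there is no change at the digits printed from compound 2 to compound 3 (within the scatter).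

Compound 4 is `O=C(O)c1ccc(-c2ccc3c(O)cccc3c2)cc1`. It differs from compound 1 as follows: carboxy in place of hydrogen on an aromatic carbon. The two steps from compound 1 are the ones that bear on this change, and both were small rises that stay within the scatter. A step of the same order is expected, a number at least 4 percentage points higher from compound 1 to compound 4 (that floor lies within the scatter). Compound 4 is thus estimated to give about 14% in this assay, in a range from 5% to 26%.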

Compound 4, a percentage reported as inhibition, at one concentration (the size of the read-out at that concentration, not a potency): < 10%
Compound 4 gave a limit, no number; the forecaster's own chance of this, stated with the estimate: 30%; at least 4 percentage points between middle value and limit.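

Compound 4 gives a limit of the assay and not a number in this assay, and since compound 1 also stands at a limit, the step between them cannot be read. Set against the other two substituents at the same place, the carboxy group gives a number at least 6 percentage points lower from compound 3 to compound 4 (that floor lies within the scatter) and a number at least 6 percentage points lower from compound 2 to compound 4 (that floor lies within the scatter). The new information is therefore modest: para to a large group, the cyano and acetyl groups give numbers, whereas the carboxy group leaves the read-out at the floor, though neither step is beyond the scatter: the limit of < 10% in this assay, at which 2 of the 4 values shown sit.

Going by these compounds, whether an amine or a methyl ester at this place would raise the read-out clearly beyond the scatter remains open. Also open, on these data alone, is whether a longer chain there would do so.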